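Swapping One Aryl Amide for Another at the Limit

The compounds below may be only part of what the source reports. "The series", "measured", "known", "first", "only" and "open" are said of these compounds alone.

In an ADME assay on L02 cells (Homo sapiens) for antiproliferative activity, read by MTT assay, with a stated time of 48 h (a lower number here means a stronger inhibitor, a higher number a weaker inhibitor), compound 1 (`CCn1c(C(=O)NCCCN(C)C)ccc1C(CC)(CC)c1ccc(OCCC(O)(CC)CC)c(C)c1`) gives 2420 nM. Compound 2 (`C#CCCOC(=O)c1ccc(C(CC)(CC)c2ccc(OCCC(O)(CC)CC)c(C)c2)n1CC`) gives > 50000 nM, which is a limit of the assay and not a number. Compound 3 (`CCn1c(C(=O)Nc2ccc(OC(F)(F)F)cc2)ccc1C(CC)(CC)c1ccc(OCCC(O)(CC)CC)c(C)c1`) gives > 50000 nM, which is likewise a limit. Compound 3 therefore stands at the limit of > 50000 nM in this assay, at which 2 of the 3 values shown sit.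

Compound 4 (`CCn1c(C(=O)Nc2cccc(C(F)(F)F)c2)ccc1C(CC)(CC)c1ccc(OCCC(O)(CC)CC)c(C)c1`) has not yet been measured. It carries 3-(trifluoromethyl)phenyl in place of 4-(trifluoromethoxy)phenyl on an amide-type nitrogen.

The nearest measured change is an at least 20-fold higher number from compound 1 to compound 3 (1.31 log units; beyond the scatter), a large step that put 4-(trifluoromethoxy)phenyl in place of 3-(dimethylamino)propyl on that same nitrogen. A second large step, an at least 20-fold higher number from compound 1 to compound 2 (1.31 log units; beyond the scatter), also moved away from the 3-(dimethylamino)propyl amide. By contrast, a step that the two limits leave unreadable from compound 2 to compound 3 gives no readable size. Going by the values given here, no measured step exchanges one aryl group on this nitrogen for another, so the evidence is indirect. Compound 4 keeps an aryl group where compound 3 has one, and it has no 3-(dimethylamino)propyl group, so it is expected to remain on the weak side of this assay, with no change beyond the scatter. The expected step is a number no higher from compound 3 to compound 4 (the limit leaves the size open). For compound 4 the estimate is 50000 nM, with an expected range from 15000 nM to 80000 nM.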

Compound 4, half-maximal inhibitory concentration: > 50000 nM
Compound 4 was reported as a limit; the forecaster's own chance of this, stated with the estimate: 75%; the middle value sits exactly at the limit.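

Replacing 3-(dimethylamino)propyl on the amide-type nitrogen with 3-(trifluoromethyl)phenyl gives an at least 20-fold higher number from compound 1 to compound 4 (1.31 log units; beyond the scatter), so the large step seen earlier with 4-(trifluoromethoxy)phenyl is not confined to that one aryl group. Compound 2, compound 3 and compound 4, the three compounds shown without the 3-(dimethylamino)propyl amide, now share one reading in this assay, and that reading is a limit and not a number: the limit of > 50000 nM in this assay, at which 3 of the 4 values shown sit. The steps from compound 3 to compound 4 and from compound 2 to compound 4 cannot be read, as both ends of each are limits, so the exchange of one aryl group for the other has no readable size.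

Compound 1 alone gives a number here, which leaves open how far any of the other three lies beyond the limit and whether the two aryl amides differ at all. Also open, on these data alone, is whether the reading of compound 1 depends on the dimethylamino group itself, or whether a primary amine, a morpholine or a carboxylic acid at the end of the same chain on that nitrogen would give a similar value.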